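Amino in Place of Hydrogen: Compound 2 to Compound 4

A few compounds are considered here, and "the series" means these few. Any claim that something is new, unique, unknown or untested is made for them only; others in the source may bear on it.

Compound 2 `ClCc1ccccc1Cn1cnc2c(Cl)ncnc21` stands highest of the two numbers in a functional assay on HOP-92 cells (Homo sapiens) for cytotoxicity, read by sulforhodamine B assay, with a stated time of 48 h (on this read-out higher numbers stand for weaker inhibition of growth and lower numbers for stronger inhibition of growth), giving 4260 nM. Its nearest neighbour, compound 1 `ClCc1ccccc1Cn1cnc2c(Cl)nc(Cl)nc21`, gives 970 nM in this assay; the step of a 4.4-fold higher number from compound 1 to compound 2 (0.64 log units; beyond the scatter) follows the loss of a chloro group. For compound 3 `ClCc1cccc(Cn2cnc3ncnc(Cl)c32)c1` the result in this assay is "not determined" (no result reported).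

Compound 4 `Nc1nc(Cl)c2ncn(Cc3ccccc3CCl)c2n1` differs from compound 2 by amino in place of hydrogen on an aromatic carbon. Going by the values given here, no measured step covers this change directly: the only step known, a 4.4-fold higher number from compound 1 to compound 2 (0.64 log units; beyond the scatter), concerns removal of chloro from compound 1, not entry of amino. The aromatic carbon touched in compound 4 is the one that bears chloro in compound 1, so that step gives a direction but no firm size for a different group on it. A modest step toward a lower number is therefore expected in this assay for compound 4, namely a 2.1-fold lower number from compound 2 to compound 4 (0.33 log units; beyond the scatter). Compound 4 is estimated at 2000 nM, with a range from 700 nM to 6000 nM.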

Compound 4, concentration for total growth inhibition: 30900 nM
The estimate for compound 4 lay 15-fold (1.19 log units) below the measured number, outside the stated range (above it).
By their numbers in this assay, from the lowest: compound 1; then compound 2; then compound 4.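

At the aromatic carbon between two ring nitrogen atoms, amino does not act like hydrogen: in this assay the number moves on further, a 7.3-fold higher number from compound 2 to compound 4 (0.86 log units; beyond the scatter), and the full span at this carbon is a 32-fold higher number from compound 1 to compound 4 (1.50 log units; beyond the scatter). Going by these compounds alone, the earlier step showed only that the number rises when chloro gives way to hydrogen; the three groups now rank chloro, hydrogen, amino from the lowest number to the highest, each step beyond the scatter, so hydrogen does not mark the upper end at this position. No measurement available here bears on why amino stands highest.

Open, going by these compounds, is whether a methylamino, methoxy or fluoro group at this carbon would fall within this order or outside it. Also open, on these data alone, is whether the order would hold with a hydroxymethyl group in place of the chloromethyl group.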